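Naphthalene for methoxyphenyl on a dichotomous pyrazoline series

The source may hold more compounds than are shown below. What is called first, only, known or untested is meant among the compounds shown, and "the series" means these compounds.

Measured compounds:
compound 1 `COc1ccc(C2=NN(C3=NC(=O)/C(=C4\C(=O)Nc5ccc(Br)cc54)S3)C(c3ccc(OC)cc3)C2)cc1` with 270 nM
compound 2 `COc1ccc(C2CC(c3ccc4ccccc4c3)=NN2C2=NC(=O)/C(=C3\C(=O)Nc4ccc(Br)cc43)S2)cc1` with 59 nM
compound 3 `COc1ccc(C2=NN(C3=NC(=O)/C(=C4\C(=O)Nc5ccccc54)S3)C(c3ccc(Cl)cc3)C2)cc1` with 100000 nM

In a functional assay on cells (Cancer cell lines, Homo sapiens) for cytotoxicity, read by sulforhodamine B assay, with a stated time of 48 h (a lower number here means a stronger inhibitor of growth, a higher number a weaker inhibitor of growth), compound 3 stands highest of the three. The difference between the core of compound 1 and the core of compound 3 is not broken down here. Compound 4 `O=C1N=C(N2N=C(c3ccc4ccccc4c3)CC2c2ccc(Cl)cc2)S/C1=C1/C(=O)Nc2ccccc21` is not yet measured; from compound 3 it differs by naphthalen-2-yl in place of 4-methoxyphenyl on a carbon with a double bond to nitrogen, which is the same kind of change as naphthalen-2-yl in place of 4-methoxyphenyl on a carbon with a double bond to nitrogen, where the ring atom two ring bonds away bears a 4-methoxyphenyl group rather than a 4-chlorophenyl group. That earlier change gave a 4.6-fold lower number from compound 1 to compound 2 (0.66 log units; beyond the scatter). For compound 4 a step of a 3.3-fold lower number from compound 3 to compound 4 (0.52 log units; beyond the scatter) is expected, resting on that earlier step and on compound 3 giving 100000 nM in this assay. Compound 4 is therefore estimated at 30000 nM, between 5000 nM and 100000 nM.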

Compound 4, concentration for 50% growth inhibition: 400 nM
Compound 4: the middle estimate sits 75-fold (1.88 log units) above what was measured, and the stated range ends above it.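

In this assay, naphthalen-2-yl in place of 4-methoxyphenyl gave a 250-fold lower number from compound 3 to compound 4 (2.40 log units; beyond the scatter), so the number fell on both cores, but by very different amounts: the same change on two cores in this assay, a 4.6-fold lower number (0.66 log units; beyond the scatter) from compound 1 to compound 2 and a 250-fold lower number (2.40 log units; beyond the scatter) from compound 3 to compound 4, 55-fold (1.74 log units) apart, beyond the scatter of two such steps

The direction of the change carried over between these two pairs, but the size of the step on one core did not foretell its size on the other. The two cores differ in more than one place, and the compounds shown do not reveal which difference goes with the larger step.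

On these data alone, it remains open whether an amine or a carboxylic acid on the naphthalen-2-yl group would keep the low numbers in this assay. As far as these compounds go, whether the step would be large or modest on a third core also remains open.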